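This account rests on a few compounds, and the source may have more. Where it says the series, first, only, none or still open, it means among the compounds named here.

Compound 1 `NC(=O)c1ccc2[nH]c(-c3ccc(OCCCO)cc3)nc2c1` was examined in a physicochemical assay for solubility, with a stated time of 3 days, at pH 2 (on this read-out higher numbers stand for higher solubility and lower numbers for lower solubility), where compound 1 gives 185000 nM. Of the two numbers reported, compound 1 has the higher, but compound 2 `NC(=O)c1ccc2[nH]c(-c3ccc(OCCC4CCN(Cc5ccccc5)CC4)cc3)nc2c1`, which gives 110000 nM, sits within the scatter of it. Compound 3 `COc1ccc(CN2CCC(CCOc3ccc(-c4nc5cc(C(N)=O)ccc5[nH]4)cc3)CC2)cc1` is reported only as a limit, > 400000 nM, this being (the limit of > 400000 nM in this assay, at which 1 of the 3 values shown sits). Among the compounds with values here, the single measured step, an at least 3.6-fold higher number from compound 2 to compound 3 (0.56 log units; beyond the scatter), concerns a different position and does not bear on the change considered here. Compound 4 `CC(=O)N1CCCCC1CCOc1ccc(-c2nc3cc(C(N)=O)ccc3[nH]2)cc1` differs from compound 1 by 1-acetylpiperidin-2-yl in place of hydroxymethyl on a saturated chain carbon, two bonds along the chain from an oxygen on an aromatic ring. Within the data shown here, with no measured step at this position, the expectation rests on compound 1 alone, and a modest fall is expected, a 3.1-fold lower number from compound 1 to compound 4 (0.49 log units; beyond the scatter). Compound 4 is therefore estimated to give 60000 nM, within a range from 15000 nM to 250000 nM.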

Compound 4, solubility: > 400000 nM
Compound 4: only a limit was reported; the forecaster's own chance of this, stated with the estimate: 10%; middle value at least 6.6-fold (0.82 log units) from the limit.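

The exchange of hydroxymethyl for 1-acetylpiperidin-2-yl is read in this assay as an at least 2.1-fold higher number from compound 1 to compound 4 (0.33 log units; beyond the scatter) and gives this position its first measured step. This position therefore carries the ring-bearing group with no fall in the number. On these data alone, the value of compound 4 is a limit, so the full size of the step stays unknown: (the limit of > 400000 nM in this assay, at which 2 of the 4 values shown sit).

The compounds shown leave open whether the ring or the acetyl accounts for the step. They also leave open how a piperidine without acetyl, a primary amine or a carboxylic acid would read at this position.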